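A few compounds are considered here, and "the series" means these few. Any claim that something is new, unique, unknown or untested is made for them only; others in the source may bear on it.

Of the compounds shown here, two have been tested so far in a functional assay on HEK293 cells for antagonist activity at metabotropic glutamate receptor 5 (Rattus norvegicus), read by calcium flux; on this read-out lower numbers stand for stronger inhibition and higher numbers for weaker inhibition. Compound 1 `Cc1cccc(C#Cc2cc(I)cc(C#N)c2)n1` gives 0.71 nM in this assay, and compound 2 `N#Cc1cc(C#Cc2ccccn2)cc([N+](=O)[O-])c1` gives 1.32 nM. The two values lie within the usual scatter of each other, so on these numbers compound 2 cannot be told apart from compound 1.

Compound 3 `N#Cc1cc(I)cc(C#Cc2ccccn2)c1` has not yet been measured. It differs from compound 2 in one place: iodo in place of nitro on an aromatic carbon. Among the measured compounds shown here, no step between measured compounds carries this same change, so no size can be read off. Since compound 3 shares the iodo group and the cyano group of compound 1, and compound 1 gives 0.71 nM in this assay, the value for compound 3 is expected to stay in the same region, with no step beyond the scatter. For compound 3 the estimate in this assay is 1 nM, with a range from 0.35 nM to 3 nM. This estimate corresponds to an expected step of a 1.3-fold lower number from compound 2 to compound 3 (0.12 log units; within the scatter).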

Compound 3, half-maximal inhibitory concentration: 0.66 nM
Compound 3: the middle estimate sits 1.5-fold (0.18 log units) above what was measured; measured number inside the range.
By their numbers in this assay, from the lowest: compounds 3, 1 and 2 (each within the scatter of the next).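

In this assay, the position meta to the cyano group accepts iodo in place of nitro with a 2.0-fold lower number from compound 2 to compound 3 (0.30 log units; within the scatter) and no step beyond the scatter, so a single heavy atom with no hydrogen-bond acceptors cannot be told apart from a three-atom group with two. Hydrogen in place of methyl on an aromatic carbon gives a 1.1-fold lower number from compound 1 to compound 3 (0.03 log units; within the scatter) and shows that, with iodo and cyano present, the number stays in the same region with or without that methyl. No measurement shown here accounts for either result.

Among the compounds shown here, every step so far lies within the scatter, so no group has yet been seen to move the number at either place. Going by these compounds, it remains open whether an amine or a carboxylic acid in place of iodo, or a longer chain in place of methyl, would do so.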